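A few compounds are considered here, and "the series" means these few. Any claim that something is new, unique, unknown or untested is made for them only; others in the source may bear on it.

Measured so far in a functional assay on KB cells (Homo sapiens) for cytotoxicity, read by MTT assay, with a stated time of 72 h; a lower number here means a stronger inhibitor, a higher number a weaker inhibitor:

compound 1, `O=S(=O)(c1ccccc1)c1nc2ccccc2nc1Nc1ccc(F)cc1`: > 50000 nM, which is a limit of the assay rather than a number.
compound 2, `O=S(=O)(c1ccccc1)c1nc2ccccc2nc1Nc1ccc(Cl)cc1`: 41200 nM.
compound 3, `O=S(=O)(c1ccc(Br)cc1)c1nc2ccccc2nc1Nc1ccc(F)cc1`: 2280 nM.

Compound 2 differs from compound 1 by chloro in place of fluoro on an aromatic carbon. In this assay that change gives an at least 1.2-fold lower number from compound 1 to compound 2 (0.08 log units; that floor lies within the scatter), so on the evidence of this one pair the swap does little that can be told apart from repeat-to-repeat noise. Compound 3 differs from compound 1 by bromo in place of hydrogen on an aromatic carbon, and here the change gives an at least 21-fold lower number from compound 1 to compound 3 (1.34 log units; beyond the scatter); compound 3 also stands well clear of compound 2 in this assay.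

Compound 4, `O=S(=O)(c1ccc(Br)cc1)c1nc2ccccc2nc1Nc1ccc(Cl)cc1`, has not yet been measured. It differs from compound 3 by chloro in place of fluoro on an aromatic carbon. This is the same change as the one from compound 1 to compound 2, made at the same place, and it occurs twice among these four compounds; the two cores on which it is made differ by bromo in place of hydrogen on an aromatic carbon. Because the earlier step of an at least 1.2-fold lower number from compound 1 to compound 2 (0.08 log units; that floor lies within the scatter) sits at its floor and within the scatter, only a small step is expected from compound 3 to compound 4: a 1.4-fold lower number from compound 3 to compound 4 (0.15 log units; within the scatter). Compound 4 is therefore estimated at 1600 nM in this assay, with the expected range running from 600 nM to 4500 nM.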

Compound 4, half-maximal inhibitory concentration: 11600 nM
Compound 4: the middle estimate sits 7.3-fold (0.86 log units) below what was measured; measured number above the stated range.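

In this assay, chloro in place of fluoro gives a 5.1-fold higher number from compound 3 to compound 4 (0.71 log units; beyond the scatter), and this does not match the same change made on the core without bromo: the same change on two cores in this assay, an at least 1.2-fold lower number (0.08 log units; that floor lies within the scatter) from compound 1 to compound 2 and a 5.1-fold higher number (0.71 log units; beyond the scatter) from compound 3 to compound 4, at least 6.1-fold (0.79 log units) apart, beyond the scatter of two such steps. Bromo in place of hydrogen gives a 3.6-fold lower number from compound 2 to compound 4 (0.55 log units; beyond the scatter), and this too stands apart from the same change made on the other core: the same change on two cores in this assay, an at least 21-fold lower number (1.34 log units; beyond the scatter) from compound 1 to compound 3 and a 3.6-fold lower number (0.55 log units; beyond the scatter) from compound 2 to compound 4, at least 6.1-fold (0.79 log units) apart, beyond the scatter of two such steps. In these four compounds, then, neither change keeps a fixed size from one core to the other, although this rests on a single pair of cores and does not show why the steps differ, and with compound 1 resting on a limit of the assay rather than a number, the true size of both earlier steps stays unknown: the limit of > 50000 nM in this assay, at which 1 of the 4 values shown sits.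

The compounds shown leave open whether a methoxy group, a nitrile or an amine in place of the fluoro or chloro would also give steps that change with the core. They also leave open whether iodo or methyl in place of the bromo would give a step like the one seen with bromo, and whether any of these steps would hold on a third core.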